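Sulfamoyl in Place of a Fluorinated Carbinol

The compounds below may be only part of what the source reports. "The series", "measured", "known", "first", "only" and "open" are said of these compounds alone.

Compound 2 `C#CCC(O)(c1ccc(N2CCN(S(=O)(=O)c3ccc(N)nc3)C[C@@H]2C#CC)cc1)C(F)(F)F` gives 130 nM in an assay on cells (Hepatocyte) for inhibition of glucokinase regulatory protein (Mus musculus), with stated times of 20 min and 40 min (a lower number here means that less compound is needed, a higher number that more compound is needed for the effect), the highest of the two numbers available, and its nearest neighbour, compound 1 `CC#C[C@H]1CN(S(=O)(=O)c2ccc(N)nc2)CCN1c1ccc([C@@](O)(CO)C(F)(F)F)cc1`, gives 89 nM; the step of a 1.5-fold higher number from compound 1 to compound 2 (0.16 log units; within the scatter) stays within the scatter. Compound 3 `CC#C[C@H]1CN(S(=O)(=O)c2ccc(N)nc2)CCN1c1ccc(S(N)(=O)=O)cc1` has not yet been measured. It differs from compound 2 in that (a group of 4 heavy atoms (1 nitrogen, 2 oxygen, 1 sulfur; no ring) in place of a group of 9 heavy atoms (5 carbon, 1 oxygen, 3 fluorine; no ring), on an aromatic carbon). For the measured compounds named here, the one measured step, a 1.5-fold higher number from compound 1 to compound 2 (0.16 log units; within the scatter), exchanges one group for another at this same aromatic carbon without reaching beyond the scatter, but neither group resembles sulfamoyl, so the measured data give no direct guide to this exchange. The expectation is therefore uncertain, and a moderate rise in this assay is expected, a 2.3-fold higher number from compound 2 to compound 3 (0.36 log units; beyond the scatter), given that compound 2 already shows 130 nM. Compound 3 is estimated at 300 nM, with a range from 80 nM to 1200 nM.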

Compound 3, half-maximal effective concentration: 37 nM
Compound 3: the middle estimate sits 8.1-fold (0.91 log units) above what was measured; the whole stated range lies above it.
By their numbers in this assay, from the lowest: compound 3; then compounds 1 and 2 (each within the scatter of the next).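

At this aromatic carbon, para to a large group, the fluorinated carbinols of compound 1 and compound 2 are not needed for a low number in this assay: replacing them with sulfamoyl gives lower numbers in both single-place comparisons (a 3.5-fold lower number from compound 2 to compound 3 (0.55 log units; beyond the scatter); a 2.4-fold lower number from compound 1 to compound 3 (0.38 log units; beyond the scatter)). Both steps lie beyond the scatter, unlike the exchange between the two carbinols, so this position, which had so far shown no difference, does respond to the group placed there. The compounds shown contain no measurement that accounts for this response.

Going by these compounds, whether the lower number is particular to sulfamoyl stays open, as a methylsulfonyl group, a carboxylic acid or a primary amide at the same carbon could give a different result. For the compounds shown here, it is also open whether the step would carry over to a core other than the one these three compounds share.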